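The source may report more compounds than this note shows. Statements on the series, on what has been measured and on what is new or still open speak of the compounds shown alone.

Of the compounds shown here, three have been tested in a functional assay on HeLa cells (Homo sapiens) for antiproliferative activity, with a stated time of 48 h; on this read-out higher numbers stand for weaker inhibition and lower numbers for stronger inhibition. Compound 1 `C=C(Br)C(=O)Nc1ccc(C(=O)/C=C/c2cccc(OC)c2)cc1` gives 500 nM in this assay. Compound 2 `C=C(Br)C(=O)Nc1ccc(C(=O)/C=C/c2cc(OC)cc(OC)c2)cc1` gives 1700 nM. The two differ in one place: methoxy in place of hydrogen on an aromatic carbon. That change made a step of a 3.4-fold higher number from compound 1 to compound 2 (0.53 log units; beyond the scatter). Compound 3 `Nc1ccc(/C=C/C(=O)c2ccccc2)cc1` has a different core from compound 1, and how the two cores differ is not broken down here; in this assay compound 3 gives 36000 nM, the highest number of the three.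

Compound 4 `COc1cccc(C(=O)/C=C/c2ccc(N)cc2)c1` has not yet been measured. It differs from compound 3 by methoxy in place of hydrogen on an aromatic carbon. Within the data shown here, this is the same kind of change as the one between compound 1 and compound 2, though the surroundings are not identical: in the earlier pair the new group sat meta to a methoxy group as well as meta to a large group, whereas in compound 4 it sits only meta to a large group. On the basis of that earlier step, a similar modest rise is expected, a 1.7-fold higher number from compound 3 to compound 4 (0.22 log units; within the scatter), although the core is different and the change occurs only twice among these compounds. Compound 4 is therefore estimated at 60000 nM in this assay, within a range from 15000 nM to 200000 nM.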

Compound 4, half-maximal inhibitory concentration: 33000 nM
Compound 4: middle estimate off by 1.8-fold (0.26 log units), on the high side; the measured number falls inside the stated range.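

In this assay the methoxy swap on the core of compound 3 gives a 1.1-fold lower number from compound 3 to compound 4 (0.04 log units; within the scatter) and so leaves compound 3 and compound 4 indistinguishable. The same swap on the core of compound 1 had a clear effect, so in this series it does not carry over unchanged from one core to the other, as the two steps set side by side show: the same change on two cores in this assay, a 3.4-fold higher number (0.53 log units; beyond the scatter) from compound 1 to compound 2 and a 1.1-fold lower number (0.04 log units; within the scatter) from compound 3 to compound 4, 3.7-fold (0.57 log units) apart, beyond the scatter of two such steps. This does not show that the core alone sets the outcome, since the new group also has different surroundings in the two pairs, and one pair on each core gives no rule for any other core.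

Still open, as far as these compounds go, is how the core of compound 3 would respond to a second methoxy group on compound 4, which would be the closest match to the change from compound 1 to compound 2. Also open, from the compounds shown here alone, is whether another group in the same place, such as a hydroxyl, a fluorine or a longer ethoxy chain, would differ between the two cores in the same way.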